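Sulfoxide Tail Variation in a Piperidine Series

This account rests on a few compounds, and the source may have more. Where it says the series, first, only, none or still open, it means among the compounds named here.

Measured compounds:
Compound 1, `CN1CCC(c2ccc(Cl)cc2)C(C[S+]([O-])CCO)C1`, gives 42 nM in an assay on isolated protein for inhibition of Norepinephrine transporter (Rattus norvegicus), read by radioligand binding; a higher number here means a weaker inhibitor, a lower number a stronger inhibitor.
Compound 2, `CC(=O)OCCSCC1CN(C)CCC1c1ccc(Cl)cc1`, gives 3.6 nM in this assay.
Compound 3, `CC(=O)OCC[S+]([O-])CC1CN(C)CCC1c1ccc(Cl)cc1`, gives 29 nM in this assay.

Compound 3 stands second highest of the three numbers. Its nearest neighbour is compound 1: the step of a 1.4-fold lower number from compound 1 to compound 3 (0.16 log units; within the scatter) stays within the scatter, so the acetyl on the oxygen changes nothing that can be read. Compound 2 lies furthest away; its value and that of compound 3 differ by a wide margin, and the step of a 12-fold lower number from compound 1 to compound 2 (1.07 log units; beyond the scatter) shows how much the sulfur part of the tail can move the number.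

Compound 4, `CN1CCC(c2ccc(Cl)cc2)C(C[S+]([O-])CC(=O)N(C)C)C1`, has not yet been measured. It differs from compound 3 by dimethylcarbamoyl in place of acetoxymethyl on a saturated chain carbon bound to a sulfur.

Within the data shown here, no measured step covers this exchange. Among the measured compounds shown here, the only step on the same tail, a 1.4-fold lower number from compound 1 to compound 3 (0.16 log units; within the scatter), was small, which suggests that the end of this chain is tolerant; the large step of a 12-fold lower number from compound 1 to compound 2 (1.07 log units; beyond the scatter) concerns the sulfur itself, which compound 4 keeps unchanged from compound 3. The expectation is therefore a step of a 1.0-fold higher number from compound 3 to compound 4 (0.01 log units; within the scatter) in this assay, nothing beyond the scatter in either direction. Compound 4 is estimated at 30 nM, within a range from 10 nM to 90 nM.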

Compound 4, inhibition constant: 1250 nM
Compound 4: middle estimate off by 42-fold (1.62 log units), on the low side, and the stated range ends below it.
By their numbers in this assay, from the lowest: compound 2; then compounds 3 and 1 (each within the scatter of the next); then compound 4.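

Among these compounds, the tolerance seen at this position so far does not extend to every group. In this assay, hydroxymethyl and acetoxymethyl on the saturated chain carbon bound to a sulfur could not be told apart, yet dimethylcarbamoyl in the same place gives a 43-fold higher number from compound 3 to compound 4 (1.63 log units; beyond the scatter) and, measured against the hydroxyl-bearing tail, a 30-fold higher number from compound 1 to compound 4 (1.47 log units; beyond the scatter). Among the compounds shown here, the two steps agree in direction and are both large, so the sulfur part of the tail is not the only place where the number can move sharply, and a change at the tail end with the sulfur held constant can do so too. No measurement available here explains this loss of binding.

Cut one bond further out, the change reads 2-acetoxyethyl to (dimethylcarbamoyl)methyl, so the compounds shown cannot separate the effect of the amide from that of the different chain linking it to the sulfur. A 2-(dimethylcarbamoyl)ethyl tail would address that question, while a primary amide, a carboxylic acid or a dimethylamino group at the chain end would show how far the loss extends to other groups.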